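Swapping the Aryl Group on an Anilide Series

A few compounds are considered here, and "the series" means these few. Any claim that something is new, unique, unknown or untested is made for them only; others in the source may bear on it.

Three close relatives share one core and differ only in the aryl group carried on an amide-type nitrogen. Compound 1 `COc1ccc2c(=O)c(/C=C/C(=O)Nc3ccccc3Cl)coc2c1` gives 29900 nM in a functional assay on A549 cells (Homo sapiens) for inhibition, read by MTT assay, with a stated time of 48 h; on this read-out higher numbers stand for weaker inhibition and lower numbers for stronger inhibition; compound 2 `COc1ccc2c(=O)c(/C=C/C(=O)Nc3ccccc3C)coc2c1` gives 23400 nM, and compound 3 `COc1ccc2c(=O)c(/C=C/C(=O)Nc3ccc(F)cc3)coc2c1` gives 26800 nM. Compound 1 thus has the highest of the three numbers, yet every step from it stays within the scatter: a 1.3-fold lower number from compound 1 to compound 2 (0.11 log units; within the scatter), and a 1.1-fold lower number from compound 1 to compound 3 (0.05 log units; within the scatter); between the other two, a 1.1-fold higher number from compound 2 to compound 3 (0.06 log units; within the scatter).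

Compound 4 `COc1ccc2c(=O)c(/C=C/C(=O)Nc3ccc(C)cc3)coc2c1` is not yet measured. The change from compound 1 is 4-methylphenyl in place of 2-chlorophenyl on an amide-type nitrogen. Both measured steps bear on it: one also replaces chloro with methyl, the other also moves the substituent from a 2-substituted to a 4-substituted phenyl, and neither left the scatter. No step beyond the scatter is therefore expected in this assay, at most a small drift toward a lower number.

Compound 4 is expected to give 24000 nM, within 12000 nM to 50000 nM; this estimate implies a 1.2-fold lower number from compound 1 to compound 4 (0.10 log units; within the scatter).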

Compound 4, half-maximal inhibitory concentration: 17500 nM
Compound 4: the middle estimate sits 1.4-fold (0.14 log units) above what was measured, and the stated range covers the measured number.
By their numbers in this assay, from the lowest: compounds 4, 2, 3 and 1 (each within the scatter of the next).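

Putting 4-methylphenyl on the amide-type nitrogen in place of 2-chlorophenyl, which changes both the substituent and where it sits on the phenyl ring, gives a 1.7-fold lower number from compound 1 to compound 4 (0.23 log units; within the scatter) in this assay, so even this double change does not leave the scatter. The other two comparisons agree: exchanging fluoro for methyl on the phenyl ring gives a 1.5-fold lower number from compound 3 to compound 4 (0.19 log units; within the scatter), and 4-methylphenyl in place of 2-methylphenyl gives a 1.3-fold lower number from compound 2 to compound 4 (0.13 log units; within the scatter), so all four aryl groups shown lie within the scatter of one another at this nitrogen. Nothing at hand explains why these groups read so alike.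

The phenyl rings shown carry only chloro, methyl or fluoro. On these data alone, whether an amine or a carboxylic acid on that ring, or a longer chain in place of the aryl group, would move the number beyond the scatter remains open.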